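A few compounds are considered here, and "the series" means these few. Any claim that something is new, unique, unknown or untested is made for them only; others in the source may bear on it.

Measured so far:
compound 1, `C=CCN(C)C(=O)c1ccc(C(CC)(CC)c2ccc(OCCC(O)(CC)CC)c(C)c2)n1CC`: > 10000 nM
compound 2, `C#CC(C)OC(=O)c1ccc(C(CC)(CC)c2ccc(OCCC(O)(CC)CC)c(C)c2)n1CC`: 2650 nM
compound 3, `CCn1c(C(=O)N(C)CC(=O)O)ccc1C(CC)(CC)c1ccc(OCCC(O)(CC)CC)c(C)c1`: 89 nM

All three share one core and differ only in the group attached to a carbonyl carbon. In an assay on cells for agonist activity at vitamin D3 receptor (Homo sapiens), with a stated time of 96 h (a higher number here means that more compound is needed for the effect, a lower number that less compound is needed), compound 1 gives > 10000 nM, which is a limit of the assay and not a number (the limit of > 10000 nM in this assay, at which 1 of the 3 values shown sits). Compound 2 gives 2650 nM in this assay, and compound 3 gives 89 nM. Compound 3 therefore has the lowest number of the two that are numbers; its nearest neighbour is compound 2, and the step is a 30-fold lower number from compound 2 to compound 3 (1.47 log units; beyond the scatter). The step of an at least 110-fold lower number from compound 1 to compound 3 (2.05 log units; beyond the scatter) runs in the same direction, and so does an at least 3.7-fold lower number from compound 1 to compound 2 (0.57 log units; beyond the scatter).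

Compound 4, `CCn1c(C(=O)NC(CO)CCO)ccc1C(CC)(CC)c1ccc(OCCC(O)(CC)CC)c(C)c1`, keeps the core and changes the same position: a group of 7 heavy atoms (4 carbon, 1 nitrogen, 2 oxygen; no ring) in place of a group of 6 heavy atoms (3 carbon, 1 nitrogen, 2 oxygen; no ring), on a carbonyl carbon. The carboxy group of compound 3 leaves, and the step of an at least 110-fold lower number from compound 1 to compound 3 (2.05 log units; beyond the scatter) shows that its arrival went with a large fall in the number. Going the other way, a rise is expected for compound 4, though the new group still carries an amide-type nitrogen as compound 3 does, so the rise is estimated to be smaller than that step: a 9.0-fold higher number from compound 3 to compound 4 (0.95 log units; beyond the scatter). Compound 4 is thus expected to give about 800 nM in this assay, likely between 150 nM and 5000 nM.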

Compound 4, half-maximal effective concentration: 2490 nM
For compound 4 the middle estimate is 3.1-fold (0.49 log units) below the measured one; low and high end bracket the measured number.
By their numbers in this assay, from the lowest: compound 3; then compounds 4 and 2 (each within the scatter of the next). At a limit, above all of these: compound 1.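

Within the data shown here, of the groups on this carbonyl carbon, only the one holding a carboxy group reaches a low number in this assay, and replacing it gives this step: a 28-fold higher number from compound 3 to compound 4 (1.45 log units; beyond the scatter). A chain with more hydrogen-bond donors but no carboxy group therefore does not stand in for it. The hydroxy-bearing group does no more than the (1-methylprop-2-yn-1-yl)oxy group, at a 1.1-fold lower number from compound 2 to compound 4 (0.03 log units; within the scatter), while it does differ from the allyl(methyl)amino group, at an at least 4.0-fold lower number from compound 1 to compound 4 (0.60 log units; beyond the scatter). That last step rests on a value for compound 1 that is a limit of the assay and not a number: the limit of > 10000 nM in this assay, at which 1 of the 4 values shown sits.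

The compounds shown leave open whether the carboxy group alone accounts for the low number of compound 3, or whether the methyl on the amide-type nitrogen and the length of the chain also matter. A carboxylic acid on a longer chain, the same acid without that methyl, or an amine in place of the carboxy group would each separate these possibilities.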